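The source may report more compounds than this note shows. Statements on the series, on what has been measured and on what is new or still open speak of the compounds shown alone.

For the measured compounds named here, compound 2 `COc1ccc(-c2nc(SCC(=O)c3sc(-c4ccc(Cl)cc4)nc3C)[nH]c(=O)c2C#N)cc1` gives 88.3% in a functional assay on U-87MG ATCC cells for antiproliferative activity against U-87 MG (Homo sapiens), read by MTT assay, with a stated time of 48 h, tested at 10 uM (a higher number here means a weaker effect of the compound at the concentration tested, a lower number a stronger effect), the smaller of the two numbers measured so far, but compound 1 `Cc1nc(-c2ccc(Cl)cc2)sc1C(=O)CSc1nc(-c2ccc(Cl)c(Cl)c2)c(C#N)c(=O)[nH]1`, with 97.1%, sits within the scatter of it, so the two cannot be told apart on the data. Going by the values given here, the only measured step, a number 8.8 percentage points lower from compound 1 to compound 2 (within the scatter), is likewise within the scatter. Compound 3 `COc1cccc(-c2nc(SCC(=O)c3sc(-c4ccc(Cl)cc4)nc3C)[nH]c(=O)c2C#N)c1` has not yet been measured in this assay; it differs from compound 2 by 3-methoxyphenyl in place of 4-methoxyphenyl on an aromatic carbon. Among the compounds with values here, no measured step moves the methoxy group around the phenyl ring, so there is no direct precedent for this change. Within the data shown here, the one step that exchanges the aryl group at this place, a number 8.8 percentage points lower from compound 1 to compound 2 (within the scatter), was within the scatter, which is the only guide available. Compound 3 is therefore expected to show a number 1.7 percentage points higher from compound 2 to compound 3 (within the scatter), that is, no step beyond the scatter. In this assay compound 3 is estimated at 90%, with a range from 76% to 100%, a number close to that of compound 2.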

Compound 3, a percentage reported as activity, at one concentration (the size of the read-out at that concentration, not a potency): 89.7%
Compound 3: the middle estimate sits 0.3 percentage points above what was measured, and the stated range covers the measured number.
By their numbers in this assay, from the lowest: compounds 2, 3 and 1 (each within the scatter of the next).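

Placing the methoxy group on the 3-position of the phenyl ring instead of the 4-position is the first measured change that alters only where this substituent sits, and in this assay it gives a step that stays within the scatter (a number 1.4 percentage points higher from compound 2 to compound 3 (within the scatter)). The exchange of 3,4-dichlorophenyl for 3-methoxyphenyl on the carbon next to the ring nitrogen and ortho to the cyano group also stays within the scatter (a number 7.4 percentage points lower from compound 1 to compound 3 (within the scatter)), so 3,4-dichlorophenyl, 4-methoxyphenyl and 3-methoxyphenyl cannot be told apart at this place at the single concentration tested. No evidence is available that would explain this result.

Going by these compounds, whether an amine or a carboxylic acid on this phenyl ring, or a longer chain in place of the methoxy group, would give a step beyond the scatter remains open. On these data alone, the 4-chlorophenyl group and the rest of the shared core are the same in all three compounds, so what a change elsewhere would do in this assay also remains unknown.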